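A few compounds are considered here, and "the series" means these few. Any claim that something is new, unique, unknown or untested is made for them only; others in the source may bear on it.

In a functional assay on SK-OV-3 cells (Homo sapiens) for cytotoxicity, read by spectrophotometry, with a stated time of 72 h (on this read-out higher numbers stand for weaker inhibition and lower numbers for stronger inhibition), compound 1 (`COc1ccc(-c2cccc(=O)n2-c2cc(OC)c(OC)c(OC)c2)cc1O`) sits at < 10 nM, which is a limit of the assay and not a number. Among the compounds with values here, compound 2 (`COc1cc(-n2c(-c3cccc(F)c3)cccc2=O)cc(OC)c1OC`) gives 472 nM, the only true number so far. Compound 3 (`COc1cc(-n2c(-c3cccc(O)c3)cccc2=O)cc(OC)c1OC`) has not yet been measured. The change from compound 2 is hydroxy in place of fluoro on an aromatic carbon, meta to a large group, so that 3-fluorophenyl becomes 3-hydroxyphenyl. Within the data shown here, one measured step bears on this, an at least 47-fold higher number from compound 1 to compound 2 (1.67 log units; beyond the scatter), which is large and beyond the scatter. In that step 3-fluorophenyl replaces 3-hydroxy-4-methoxyphenyl, so the hydroxy and the methoxy are lost together and the data do not separate them. Compound 3 has the hydroxy of compound 1 but not its methoxy, so only part of an at least 47-fold higher number from compound 1 to compound 2 (1.67 log units; beyond the scatter) is expected to come back. A moderate step towards lower numbers in this assay is therefore expected, though one of uncertain size. The estimated step is a 5.2-fold lower number from compound 2 to compound 3 (0.72 log units; beyond the scatter). Compound 3 is expected at 90 nM, with an estimated range from 15 nM to 400 nM.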

Compound 3, half-maximal inhibitory concentration: 1460 nM
Compound 3: the middle estimate sits 16-fold (1.21 log units) below what was measured, outside the stated range (above it).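

Hydroxy in place of fluoro on this aromatic carbon, meta to a large group, does not lower the number in this assay: the change gives a 3.1-fold higher number from compound 2 to compound 3 (0.49 log units; beyond the scatter). Without the methoxy of compound 1, 3-hydroxyphenyl therefore does worse here than 3-fluorophenyl, and the hydroxy alone recovers no part of an at least 47-fold higher number from compound 1 to compound 2 (1.67 log units; beyond the scatter). Hydrogen in place of methoxy gives an at least 140-fold higher number from compound 1 to compound 3 (2.16 log units; beyond the scatter), so the hydroxy of compound 1 goes with a low number only while the methoxy is present, and the size of this step rests on a limit for compound 1, not a number: the limit of < 10 nM in this assay, at which 1 of the 3 values shown sits.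

Still open, from the compounds shown here alone, is whether the methoxy of compound 1 would hold the number down by itself, or whether the low number needs the hydroxy and the methoxy together. Also open, going by these compounds, is where an amine or a chlorine in place of fluoro on this aromatic carbon would fall relative to 3-fluorophenyl and 3-hydroxyphenyl.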